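Amide trimming on a shared core: from propyl to dimethyl

The compounds below may be only part of what the source reports. "The series", "measured", "known", "first", "only" and "open" are said of these compounds alone.

Of the compounds shown here, three have been measured in an assay on isolated protein for inhibition of MAP kinase-interacting serine/threonine-protein kinase 2 (Homo sapiens), read by HTRF, in the presence of a further agent that is not named here; a higher number here means a weaker inhibitor, a lower number a stronger inhibitor. Compound 1 `COC(=O)c1cccc(C#Cc2ccccc2Nc2ncnc3ccc(Cl)nc23)c1` gives 4200 nM. Compound 2 `CCCNC(=O)c1oc2ccc(Nc3ncnc4ccc(Cl)nc34)cc2c1C` gives 1900 nM, the lowest of the two numbered values. Compound 3 `O=C(c1cccc(C#Cc2ccccc2Nc2ncnc3ccc(Cl)nc23)c1)N1CCOCC1` reaches only a limit of the assay, > 10000 nM. Going by the values given here, only one single change has been measured so far: an at least 2.3-fold higher number from compound 1 to compound 3 (0.37 log units; beyond the scatter), which rests on (the limit of > 10000 nM in this assay, at which 1 of the 3 values shown sits).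

Compound 4 `Cc1c(C(=O)N(C)C)oc2ccc(Nc3ncnc4ccc(Cl)nc34)cc12` is not yet measured. It differs from compound 2 in one place: dimethylamino in place of propylamino on a carbonyl carbon. Among the compounds with values here, the one measured step, an at least 2.3-fold higher number from compound 1 to compound 3 (0.37 log units; beyond the scatter), also alters the group on a carbonyl carbon, but on a different arm of a different core, and it replaces methoxy rather than an amino group; it is at most a loose guide. It points toward a higher number when the group on the carbonyl carbon is changed, so a modest rise is expected for compound 4, as a 1.7-fold higher number from compound 2 to compound 4 (0.23 log units; within the scatter). Compound 4 is therefore estimated at 3200 nM, within a range from 1200 nM to 8500 nM.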

Compound 4, half-maximal inhibitory concentration: 2200 nM
Beside the measured number, compound 4's estimate is 1.5-fold (0.16 log units) above it; the range from low to high includes it.
By their numbers in this assay, from the lowest: compounds 2, 4 and 1 (each within the scatter of the next, the first and the last beyond it). At a limit, above all of these: compound 3.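

On this carbonyl carbon, trading propylamino for dimethylamino gives, in this assay, a 1.2-fold higher number from compound 2 to compound 4 (0.06 log units; within the scatter) and so leaves the reading within the usual scatter. The amide hydrogen is gone in compound 4, yet the number does not move beyond that scatter, so on this core the hydrogen shows no sign of being needed, and a change on a carbonyl carbon need not shift the number, something the earlier step on a different core could not show. Nothing measured here accounts for this flat result.

Going by these compounds, whether a primary amide, a piperidine amide or a carboxylic acid on this carbonyl carbon would hold the number remains open. So does the effect of a longer chain ending in an amine.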